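Moving the trifluoromethyl group around the ring

A few compounds are considered here, and "the series" means these few. Any claim that something is new, unique, unknown or untested is made for them only; others in the source may bear on it.

Two compounds share a core and differ only in the group on one end of the urea. Compound 1 `COc1cc2cc(Oc3ccc(NC(=O)Nc4ccc(C)cc4)cc3)c(C)nc2cc1OC` carries a methyl there; in a functional assay on Malme-3M cells (Homo sapiens) for inhibition, read by sulforhodamine B assay, with a stated time of 48 h, tested at 10 uM (a lower number here means a stronger effect, a higher number a weaker effect of the compound at the concentration tested), compound 1 gives 94.6%. Compound 2 `COc1cc2cc(Oc3ccc(NC(=O)Nc4ccc(C(F)(F)F)cc4)cc3)c(C)nc2cc1OC` carries a trifluoromethyl instead; in this assay compound 2 gives 82.9%. Within the data shown here, the one measured step, a number 11.7 percentage points lower from compound 1 to compound 2 (beyond the scatter), is therefore a modest move towards a stronger effect, and compound 2 stands as the lower of the two numbers.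

Compound 3 `COc1cc2cc(Oc3ccc(NC(=O)Nc4cccc(C(F)(F)F)c4)cc3)c(C)nc2cc1OC` keeps the trifluoromethyl group but moves it: 3-(trifluoromethyl)phenyl in place of 4-(trifluoromethyl)phenyl on an amide-type nitrogen. Among the measured compounds shown here, no measured pair shows what happens when this group changes its position on the ring; the step from compound 1 to compound 2 concerns a different kind of change and so gives only an indirect hint. With nothing to point in either direction, the expected step of a number 0.9 percentage points lower from compound 2 to compound 3 (within the scatter) is small and within the usual scatter. In this assay compound 3 is estimated at 82%, with a plausible range from 64% to 97%.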

Compound 3, a percentage reported as activity, at one concentration (the size of the read-out at that concentration, not a potency): 7.22%
Compound 3: middle estimate off by 74.8 percentage points, on the high side; the whole stated range lies above it.
By their numbers in this assay, from the lowest: compound 3; then compound 2; then compound 1.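

The two compounds have the same atoms and the same counts under every heading, so only the place of the trifluoromethyl group on the ring changes, and in this assay that alone gives a number 75.7 percentage points lower from compound 2 to compound 3 (beyond the scatter). This step is far larger than the modest one seen when trifluoromethyl replaced methyl, a number 11.7 percentage points lower from compound 1 to compound 2 (beyond the scatter), so at this end of the urea, where the group sits counts for much more here than that swap of groups did; taken together, the two changes amount to a number 87.4 percentage points lower from compound 1 to compound 3 (beyond the scatter). Nothing available explains why moving the group has such a large effect on these cells.

On these data alone, it remains open whether the strong effect belongs to the trifluoromethyl group itself or would also appear if a nitrile, a chlorine atom or a methoxy group took its place in compound 3. As far as these compounds go, it is also open how compound 3 behaves at lower concentrations, as a reading at a single concentration shows the size of the effect and not a potency.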